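Stilbene Analogues in a Cell Growth Assay

The compounds below may be only part of what the source reports. "The series", "measured", "known", "first", "only" and "open" are said of these compounds alone.

Measured so far:
Compound 1, `Oc1cccc(/C=C/c2ccccc2O)c1`, in a functional assay on HT-29 cells (Homo sapiens) for inhibition, read by MTT assay, with a stated time of 2 days (a higher number here means a weaker inhibitor, a lower number a stronger inhibitor), compound 1 gives 27 ug/mL.
Compound 2, `Nc1ccccc1/C=C/c1cccc(O)c1`, in this assay compound 2 gives 30 ug/mL.

Compound 2 stands with the higher of the two numbers, though its nearest neighbour, compound 1, sits within the scatter of it: a 1.1-fold higher number from compound 1 to compound 2 (0.05 log units; within the scatter). Among the compounds with values here, that single step, an exchange of amino for hydroxy on the same aromatic carbon, is the only comparison available, and it did not move the number beyond the scatter.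

Compound 3, `COc1ccccc1/C=C/c1cccc(O)c1`, carries the change (methoxy in place of amino on an aromatic carbon). Within the data shown here, no measured pair shows a methoxy group entering at that place, so the one step from compound 1 to compound 2 is the only guide, and it was small. Compound 3 is therefore expected to stay close to compound 2, with no step beyond the scatter: no change at the digits printed from compound 2 to compound 3 (within the scatter). The estimate for compound 3 in this assay is 30 ug/mL, within a range from 12 ug/mL to 75 ug/mL.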

Compound 3, half-maximal inhibitory concentration: 17 ug/mL
For compound 3 the middle estimate is 1.8-fold (0.25 log units) above the measured one; the range from low to high includes it.
By their numbers in this assay, from the lowest: compounds 3, 1 and 2 (each within the scatter of the next).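

In this assay, methoxy in place of amino gives a 1.8-fold lower number from compound 2 to compound 3 (0.25 log units; within the scatter) and so joins amino and hydroxy as a third group on this aromatic carbon whose number lies within the scatter of the others. Methyl in place of hydrogen on the oxygen gives a 1.6-fold lower number from compound 1 to compound 3 (0.20 log units; within the scatter) and adds what the earlier pair could not show: methoxy, with 0 hydrogen-bond donors and more heavy atoms than either group before it, is not told apart from them here. No measurement is available to explain these numbers.

From the compounds shown here alone, whether any group at this place can give a step beyond the scatter stays open. A longer chain such as ethoxy, or a carboxylic acid, would test that, since the three groups shown are all small.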